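From neopentyl to cyclopropylmethyl: an estimate of stability

A few compounds are considered here, and "the series" means these few. Any claim that something is new, unique, unknown or untested is made for them only; others in the source may bear on it.

Compound 1 `CC(C)(C)CCn1nc(-c2cccs2)c(O)c(C2=NS(=O)(=O)c3cc(NS(C)(=O)=O)ccc3N2)c1=O`: > 1 h
Compound 2 `CC(C)(C)Cn1nc(-c2cccs2)c(O)c(C2=NS(=O)(=O)c3cc(NS(C)(=O)=O)ccc3N2)c1=O`: > 1 h

In an in vitro ADME assay on microsomes from liver (Homo sapiens) for metabolic stability, tested at 5 uM (on this read-out lower numbers stand for a shorter-lived compound and higher numbers for a longer-lived compound), compound 2 gives > 1 h, which is a limit and not a number. Compound 1 gives > 1 h, also a limit. Compound 2 thus stands with compound 1 at the limit of > 1 h in this assay, at which 2 of the 2 values shown sit.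

Compound 3 `CS(=O)(=O)Nc1ccc2c(c1)S(=O)(=O)N=C(c1c(O)c(-c3cccs3)nn(CC3CC3)c1=O)N2` differs from compound 2 by cyclopropyl in place of tert-butyl on a saturated chain carbon bound to an aromatic nitrogen, with cyclopropyl in place of tert-butyl on a saturated chain carbon bound to an aromatic nitrogen. For the measured compounds named here, the only measured step at this place is a step that the two limits leave unreadable from compound 1 to compound 2, and its size cannot be read. No step beyond the scatter is therefore expected in either direction, and the estimated step is a step that the limit leaves unreadable from compound 2 to compound 3. Compound 3 is expected at 1.2 h, within an estimated range of 0.6 h to 2.5 h.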

Compound 3, half-life: > 1 h
Compound 3: a limit, no number (the forecaster's own chance of this, stated with the estimate: 80%); the middle value lies beyond the limit too.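

No step among compound 1, compound 2 and compound 3 can be read in this assay, and all three values are limits, not numbers: the limit of > 1 h in this assay, at which 3 of the 3 values shown sit.

The compounds shown leave open whether their half-lives differ at all, and by how much.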